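The compounds below may be only part of what the source reports. "The series", "measured", "known", "first", "only" and "open" are said of these compounds alone.

Measured in a toxicity assay on cells (Fibroblast, Homo sapiens) for cytotoxicity; on this read-out lower numbers stand for stronger inhibition and higher numbers for weaker inhibition:
- Compound 1 `COc1ccc(O)c(C(=O)OC/C=C(C)/C=C/C=C(C)/C=C/C2=CCCCC2(C)C)c1`: 570000 nM
- Compound 2 `COc1cc(O)c(C(=O)OC/C=C(C)/C=C/C=C(C)/C=C/C2=CCCCC2(C)C)c(O)c1`: 14000 nM

Of these two, compound 2 has the lower number, at 14000 nM, and so shows the stronger inhibition. Compound 3 `CC(=O)Oc1ccccc1C(=O)OC/C=C(C)/C=C/C=C(C)/C=C/C1=CCCCC1(C)C` has not yet been measured. It keeps the core of compound 2 and changes only the group on a carbonyl carbon whose other neighbours are: oxygen next to a carbonyl group. The change is a group of 10 heavy atoms (8 carbon, 2 oxygen; one six-membered aromatic ring of carbon only) in place of a group of 10 heavy atoms (7 carbon, 3 oxygen; one six-membered aromatic ring of carbon only), on a carbonyl carbon, and the entering group is 2-acetoxyphenyl.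

For the measured compounds named here, one measured step bears on this change: a 41-fold lower number from compound 1 to compound 2 (1.61 log units; beyond the scatter). That large step was also a change of the group on the carbonyl carbon, so the number in this assay can move far with a change at this place. Going by the values given here, no measured compound carries the 2-acetoxyphenyl group, which leaves the size of the next step uncertain. A moderate to large move toward weaker inhibition is expected, though smaller than the measured step. The estimated step is a 7.1-fold higher number from compound 2 to compound 3 (0.85 log units; beyond the scatter). For compound 3 the expected value is 100000 nM, with an estimated range from 15000 nM to 500000 nM.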

Compound 3, half-maximal inhibitory concentration: 150000 nM
Compound 3: middle estimate off by 1.5-fold (0.18 log units), on the low side; low and high end bracket the measured number.
By their numbers in this assay, from the lowest: compound 2; then compound 3; then compound 1.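

In this assay, putting 2-acetoxyphenyl on the carbonyl carbon gives an 11-fold higher number from compound 2 to compound 3 (1.03 log units; beyond the scatter) and so reverses the direction of the earlier change at this place, toward weaker inhibition. Against 2-hydroxy-5-methoxyphenyl the same group gives a 3.8-fold lower number from compound 1 to compound 3 (0.58 log units; beyond the scatter) and thus a smaller move, which places 2-acetoxyphenyl between the two earlier groups and shows that this place supports a graded series of numbers rather than a single jump. The entering group has 0 hydrogen-bond donors against 2 in the group that leaves, yet compound 3 still sits on the stronger side of compound 1, so in these three compounds a loss of donors does not by itself give the highest number, and nothing available accounts for these differences.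

The compounds shown leave open whether the acetyl group itself matters, which a plain 2-hydroxyphenyl group or a longer acyl chain in its place would address. For the compounds shown here, they also leave open how an amine or a carboxylic acid on the aromatic ring would fare in this read-out, where only the three numbers so far mark out the range.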